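Alkyne cap swap on a uracil diol scaffold

The source may report more compounds than this note shows. Statements on the series, on what has been measured and on what is new or still open speak of the compounds shown alone.

Among the compounds with values here, in a functional assay on SW-620 cells (Homo sapiens) for antiproliferative activity, read by MTT assay, with a stated time of 72 h (a lower number here means a stronger inhibitor, a higher number a weaker inhibitor), compound 2, `O=c1[nH]c(=O)n(CCC(CO)CO)cc1C#CCc1ccccc1`, gives 72400 nM, the only true number among the two results. Compound 1, `O=c1[nH]c(=O)n(CCC(CO)CO)cc1-c1cccs1`, returns only a limit, > 100000 nM, so it sits at the limit of > 100000 nM in this assay, at which 1 of the 2 values shown sits. Compound 3, `O=c1[nH]c(=O)n(CCC(CO)CO)cc1C#CC1CC1`, carries the change (cyclopropyl in place of benzyl on a triple-bonded carbon), cyclopropyl in place of benzyl on a triple-bonded carbon. Within the data shown here, no measured pair isolates this change, so the author expects no step beyond the scatter, a 1.2-fold higher number from compound 2 to compound 3 (0.07 log units; within the scatter), with a fair chance of another limit. Compound 3 is estimated at 85000 nM, between 30000 nM and 250000 nM.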

Compound 3, half-maximal inhibitory concentration: > 100000 nM
Compound 3 gave a limit, no number; the forecaster's own chance of this, stated with the estimate: 45%; middle value at least 1.1-fold (0.07 log units) from the limit.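

In this assay, within the data shown here, cyclopropyl in place of benzyl on a triple-bonded carbon gives an at least 1.3-fold higher number from compound 2 to compound 3 (0.14 log units; that floor lies within the scatter) as the first readable step at this position. As far as these compounds go, that figure is only a floor, so the true size of the step is unknown, and nothing yet places it beyond the scatter. The remaining step cannot be read, and the limit now holds two of the three compounds: the limit of > 100000 nM in this assay, at which 2 of the 3 values shown sit.

From the compounds shown here alone, it remains open how an amine or a longer chain on the triple-bonded carbon would read in this assay and whether any such group would give a clearly lower number than compound 2.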